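Swapping the nitrophenyl end and Vero cell tolerance

This account rests on a few compounds, and the source may have more. Where it says the series, first, only, none or still open, it means among the compounds named here.

Compound 1, `CC(C)Cc1ccc(C(=O)/C=C/c2ccc(C(=O)O)cc2)cc1`, gives < 10 ug/mL, a limit of the assay.
Compound 2, `COC(=O)c1cc(-c2cccc(NC(=O)c3ccc(/C=C/C(=O)c4ccc(C)c([N+](=O)[O-])c4)cc3)c2)on1`, gives > 80 ug/mL, a limit of the assay.
Compound 3, `CCOC(=O)c1cc(-c2cccc(NC(=O)c3ccc(/C=C/C(=O)c4ccc(Cl)cc4)cc3)c2)on1`, gives > 80 ug/mL, a limit of the assay.

All three values come from an ADME assay on Vero cells (Chlorocebus sabaeus) for cytotoxicity, read by MTT assay, with a stated time of 72 h; a higher number here means that more compound is tolerated, a lower number that less compound is tolerated. None of them is a number: compound 1 sits at the lower limit, (the limit of < 10 ug/mL in this assay, at which 1 of the 3 values shown sits), while compound 2 and compound 3, which share a larger core, both sit at the upper limit, (the limit of > 80 ug/mL in this assay, at which 2 of the 3 values shown sit). Compound 2 therefore stands at the most tolerated end of what this assay can report, together with compound 3, and nothing separates the two.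

Compound 4, `COC(=O)c1cc(-c2cccc(NC(=O)c3ccc(/C=C/C(=O)c4ccc([N+](=O)[O-])cc4)cc3)c2)on1`, is not yet measured. It differs from compound 2 in one place: 4-nitrophenyl in place of 4-methyl-3-nitrophenyl on a carbonyl carbon. The change is small, and compound 3, which carries a different group on the same carbonyl carbon, also reaches the upper limit. Among the measured compounds shown here, with no measured step between compounds of this core to go by, no shift beyond the usual scatter is expected, and the step from compound 2 to compound 4 is estimated at a number no higher from compound 2 to compound 4 (the limit leaves the size open). Compound 4 is expected to give about 80 ug/mL, most likely again as a limit, within 40 ug/mL to 160 ug/mL.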

Compound 4, half-maximal cytotoxic concentration: > 20 ug/mL
Compound 4: no number, only a limit (the forecaster's own chance of this, stated with the estimate: 75%); the middle value is on the limit's open side.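

Compound 2 gives > 80 ug/mL, a limit of the assay. Compound 4 gives > 20 ug/mL, also a limit. With only limits on both sides, no step can be read from compound 2 to compound 4. The compounds shown leave open whether 4-nitrophenyl in place of 4-methyl-3-nitrophenyl on a carbonyl carbon changes how much compound is tolerated, and in which direction.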